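A few compounds are considered here, and "the series" means these few. Any claim that something is new, unique, unknown or untested is made for them only; others in the source may bear on it.

Measured so far in a physicochemical assay for solubility, read by HPLC, at pH 6.8; on this read-out higher numbers stand for higher solubility and lower numbers for lower solubility:
Compound 1 `CC(C)(C)c1cc(NC(=O)[C@@H]2CCCCN2C(=O)C2CCOCC2)no1`: 48 ug/mL
Compound 2 `CC(C)(C)c1cc(NC(=O)[C@@H]2CCCCN2C(=O)CC2CCOCC2)no1`: 52 ug/mL

Compound 2 stands alongside compound 1 on this assay; the step of a 1.1-fold higher number from compound 1 to compound 2 (0.03 log units; within the scatter) is within the scatter, so the two measured compounds cannot be told apart here.

Compound 3 `CC(C)(C)c1cc(NC(=O)[C@@H]2CCCCN2C(=O)N2CCCCC2)no1` has not been measured. The change from compound 2 is piperidin-1-yl in place of (oxan-4-yl)methyl on a carbonyl carbon. Among the measured compounds shown here, the only measured step, a 1.1-fold higher number from compound 1 to compound 2 (0.03 log units; within the scatter), replaces oxan-4-yl with (oxan-4-yl)methyl and keeps that ring with its oxygen in place; it does not cover an exchange of that group for piperidin-1-yl on the carbonyl carbon. For the measured compounds named here, no measured step therefore bears directly on the change at hand. With nothing to suggest a large move either way, the expectation for compound 3 is a step of a 1.3-fold lower number from compound 2 to compound 3 (0.11 log units; within the scatter), of roughly scatter size or somewhat lower. Compound 3 is accordingly estimated at 40 ug/mL, with a range of 15 ug/mL to 110 ug/mL.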

Compound 3, solubility: 49 ug/mL
Compound 3: middle estimate off by 1.2-fold (0.09 log units), on the low side, and the stated range covers the measured number.
By their numbers in this assay, from the lowest: compounds 1, 3 and 2 (each within the scatter of the next).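

Notes on the group on the carbonyl carbon, in this assay: the exchange of (oxan-4-yl)methyl for piperidin-1-yl gives a 1.1-fold lower number from compound 2 to compound 3 (0.03 log units; within the scatter), and the exchange of oxan-4-yl for piperidin-1-yl gives a 1.0-fold higher number from compound 1 to compound 3 (0.01 log units; within the scatter). Both steps remove the ring oxygen and bring a ring nitrogen onto the carbonyl carbon, and the count of hydrogen-bond acceptors on the group falls from one to none, yet neither step can be read as a change on this read-out. With the shared core held constant, the three groups at this position cannot be told apart, and no supporting data bear on why their numbers sit together.

Going by these compounds, whether a carboxylic acid or a longer chain on this carbonyl carbon would give a step beyond the scatter remains open. So does whether this flat picture holds with a different group in place of the tert-butyl on the core.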